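The source may hold more compounds than are shown below. What is called first, only, known or untested is meant among the compounds shown, and "the series" means these compounds.

Measured so far:
compound 1 `NC(=O)[C@@H]1CCCN1Cc1cc(=O)oc2cc(OCc3cccc(F)c3)ccc12` gives 850 nM
compound 2 `NNC(=O)Cc1cc(=O)oc2cc(OCc3cccc(Cl)c3)ccc12` gives 90 nM
compound 3 `CN(C)Cc1cc(=O)oc2cc(OCc3ccccc3)ccc12` gives 1800 nM

In an assay for inhibition of Amine oxidase [flavin-containing] B (Rattus norvegicus) (a lower number here means a stronger inhibitor, a higher number a weaker inhibitor), compound 2 gives the lowest number of the three; compound 1 and compound 3 both lie above it by more than the scatter, so compound 2 is the strongest inhibitor of this set. The unmeasured compound 4 `NCc1cc(=O)oc2cc(OCc3cccc(Cl)c3)ccc12` differs from compound 2 in a single place: amino in place of aminocarbamoyl on a saturated chain carbon bound to an aromatic carbon. Among the compounds with values here, no step between measured compounds covers this change. Because compound 3 also carries an amine on a saturated chain carbon bound to an aromatic carbon and gives 1800 nM in this assay, the step of an 11-fold higher number from compound 2 to compound 4 (1.05 log units; beyond the scatter) is expected to run upward, beyond the scatter. Compound 4 is therefore estimated at 1000 nM, with a range from 250 nM to 4000 nM.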

Compound 4, half-maximal inhibitory concentration: 15 nM
Estimate against measurement, compound 4: 67-fold (1.82 log units) above; the measured number lies below the stated range.
By their numbers in this assay, from the lowest: compound 4; then compound 2; then compound 1; then compound 3.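

In this assay, the change from aminocarbamoyl to amino on a saturated chain carbon bound to an aromatic carbon gives a 6.0-fold lower number from compound 2 to compound 4 (0.78 log units; beyond the scatter), so the aminocarbamoyl is not needed here for strong inhibition. This single-place comparison, the first in the set, shows that the lone amino group goes with a lower number on this core. Nothing measured here accounts for the step. The compounds shown leave open how a hydroxyl, a carboxylic acid or a longer aminoethyl chain would read at this place, and whether the step would hold with a different group elsewhere on the core.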